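Carboxyphenyl ether series: the step from compound 3 to compound 4

The source may hold more compounds than are shown below. What is called first, only, known or untested is meant among the compounds shown, and "the series" means these compounds.

Compound 3 `Cc1c(OCCCCOc2ccc(C(=O)O)c(Cl)c2)ccc(C(=O)CC(C)C)c1C` holds only a limit in an assay on HEK293 cells for positive allosteric modulation of metabotropic glutamate receptor 2 (Rattus norvegicus), read by thallium flux, with a stated time of 2.5 min (a higher number here means that more compound is needed for the effect, a lower number that less compound is needed), namely > 10000 nM, and so gives no single number. Compound 2 `Cc1c(OCCCCOc2ccc(C(=O)O)cc2)ccc(C(=O)CC(C)C)c1C` is recorded as "not determined" (no result reported) in this assay. Among the compounds with values here, compound 1 `Cc1c(OCCCCOc2ccccc2C(=O)O)ccc(C(=O)CC2CCCC2)c1C` gives 2580 nM in this assay and is the one entry with a number. Of the three values shown, one sits at the limit of > 10000 nM in this assay, at which 1 of the 3 values shown sits. Compound 4 `Cc1c(OCCCCOc2ccccc2C(=O)O)ccc(C(=O)CC(C)C)c1C` differs from compound 3 by 2-carboxyphenyl in place of 4-carboxy-3-chlorophenyl on an oxygen on a saturated carbon. Within the data shown here, no measured step covers this change. The expected step is toward less compound needed, an at least 1.6-fold lower number from compound 3 to compound 4 (0.22 log units; that floor lies within the scatter), since compound 1 carries the same 2-carboxyphenyl and gives 2580 nM. Compound 4 is estimated at 6000 nM, with a range from 2000 nM to 18000 nM.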

Compound 4, half-maximal effective concentration: 976 nM
Compound 4: the middle estimate sits 6.1-fold (0.79 log units) above what was measured, outside the stated range (below it).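

On the oxygen on a saturated carbon, 2-carboxyphenyl gives a single number where 4-carboxy-3-chlorophenyl does not: an at least 10-fold lower number from compound 3 to compound 4 (1.01 log units; beyond the scatter). The value of compound 3 is a limit, so this step has only a floor: the limit of > 10000 nM in this assay, at which 1 of the 4 values shown sits.

A second place also moves the value, as isopropyl in place of cyclopentyl on a saturated chain carbon bound to a carbonyl carbon gives a 2.6-fold lower number from compound 1 to compound 4 (0.42 log units; beyond the scatter).

The step to compound 4 changes the carboxyl position and removes the chlorine together, and the two changes cannot be separated here, since compound 2 has no result. From the compounds shown here alone, whether a tetrazole or an amide can stand in place of the carboxylic acid remains open.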